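Amine-tail variation on the coumarin amide series

The source may report more compounds than this note shows. Statements on the series, on what has been measured and on what is new or still open speak of the compounds shown alone.

Measured so far in a functional assay on SK-BR-3 cells (Homo sapiens) for antiproliferative activity; on this read-out lower numbers stand for stronger inhibition and higher numbers for weaker inhibition:
compound 1 `CC(C)=CCc1cc(C(=O)Nc2cc3ccc(OCC4CCCN(C)C4)c(C)c3oc2=O)ccc1O` — 1300 nM
compound 2 `CCN(C)CCCOc1ccc2cc(NC(=O)c3ccc(O)c(CC=C(C)C)c3)c(=O)oc2c1C` — 730 nM
compound 3 `CCCN(CCC)CCCOc1ccc2cc(NC(=O)c3ccc(O)c(CC=C(C)C)c3)c(=O)oc2c1C` — a limit of the assay, > 50000 nM

Compound 1 holds the highest of the two numbers given; compound 2 sits a 1.8-fold lower number from compound 1 to compound 2 (0.25 log units; within the scatter), so the two cannot be ordered. Compound 3 returned only a limit, which is where one of the three values sits (the limit of > 50000 nM in this assay, at which 1 of the 3 values shown sits).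

Compound 4 `CC(C)=CCc1cc(C(=O)Nc2cc3ccc(OCCCNCC(N)=O)c(C)c3oc2=O)ccc1O` is not yet measured. Against compound 1 the change is 2-((carbamoylmethyl)amino)ethyl in place of 1-methylpiperidin-3-yl on a saturated chain carbon bound to an oxygen on an aromatic ring. The entering group carries a secondary amine with a carbamoylmethyl arm in place of the ring nitrogen of 1-methylpiperidin-3-yl.

Within the data shown here, two measured steps bear on it. Exchanging the ring amine for ethyl(methyl)amino gave a 1.8-fold lower number from compound 1 to compound 2 (0.25 log units; within the scatter), while the bulkier dipropylamino gave an at least 38-fold higher number from compound 1 to compound 3 (1.58 log units; beyond the scatter) and an at least 68-fold higher number from compound 2 to compound 3 (1.83 log units; beyond the scatter). The tail in compound 4 is closer in size to the ethyl(methyl) case than to dipropyl, so in this assay no step beyond the scatter is expected, with some risk of a weaker number.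

Compound 4 is therefore estimated at 2000 nM, range 600 nM to 8000 nM, meaning an expected step of a 1.5-fold higher number from compound 1 to compound 4 (0.19 log units; within the scatter).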

Compound 4, half-maximal inhibitory concentration: 2290 nM
Compound 4: the middle estimate sits 1.1-fold (0.06 log units) below what was measured, and the stated range covers the measured number.
By their numbers in this assay, from the lowest: compounds 2, 1 and 4 (each within the scatter of the next, the first and the last beyond it). At a limit, above all of these: compound 3.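

In this assay, the open 2-((carbamoylmethyl)amino)ethyl tail, with no ring, stays within the scatter of the ring-bearing tail of compound 1: a 1.8-fold higher number from compound 1 to compound 4 (0.25 log units; within the scatter). Set against the ethyl(methyl)amino tail, the (carbamoylmethyl)amino change does move the number beyond the scatter, though only modestly: a 3.1-fold higher number from compound 2 to compound 4 (0.50 log units; beyond the scatter). The much larger step an at least 21-fold lower number from compound 3 to compound 4 (1.33 log units; beyond the scatter) starts from compound 3, whose value is a limit and not a number, so this tail is clearly separated from dipropylamino only as far as that limit allows: the limit of > 50000 nM in this assay, at which 1 of the 4 values shown sits.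

The compounds shown do not separate the contribution of the secondary amine from that of the carbamoylmethyl arm in compound 4. A plain methylamino tail, or a carboxylic acid in place of the terminal amide, would address that question, and a morpholine ring would test a ring tail carrying a second hetero atom.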